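Aryl variation on the oxadiazole of the thiadiazole Schiff base series

A few compounds are considered here, and "the series" means these few. Any claim that something is new, unique, unknown or untested is made for them only; others in the source may bear on it.

Compound 1 `Oc1ccccc1/C=N/c1nnc(SCc2nnc(-c3ccc(F)cc3)o2)s1` is the reference point; in a functional assay on SMMC-7721 cells (Homo sapiens) for inhibition, read by CCK-8 assay (a lower number here means a stronger inhibitor, a higher number a weaker inhibitor), compound 1 gives 13100 nM. Compound 2 `Oc1ccccc1/C=N/c1nnc(SCc2nnc(-c3ccc(Br)cc3)o2)s1` carries bromo in place of fluoro on the aromatic carbon, and in this assay compound 2 gives 18000 nM. The step of a 1.4-fold higher number from compound 1 to compound 2 (0.14 log units; within the scatter) shows that the halogen swap changes nothing that can be told apart from repeat-measurement noise. Going by the values given here, compound 2 thus has the highest of the two numbers so far, with compound 1 as its only neighbour, but the two cannot be ordered.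

Compound 3 `Cc1cccc(-c2nnc(CSc3nnc(/N=C/c4ccccc4O)s3)o2)c1` is the next member, not yet measured. It differs from compound 2 by 3-methylphenyl in place of 4-bromophenyl on an aromatic carbon. Among the compounds with values here, the only measured step that bears on this change is the halogen exchange at the same aromatic position, a 1.4-fold higher number from compound 1 to compound 2 (0.14 log units; within the scatter), which stayed within the scatter. A methyl on a different ring position is not covered by any measured pair, so the expectation rests on that single flat step: no change beyond the scatter, with wide uncertainty. Compound 3 is therefore expected to come in near 17000 nM, between 7000 nM and 45000 nM, a step of a 1.1-fold lower number from compound 2 to compound 3 (0.02 log units; within the scatter).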

Compound 3, half-maximal inhibitory concentration: 4550 nM
For compound 3 the middle estimate is 3.7-fold (0.57 log units) above the measured one; the measured number lies below the stated range.
By their numbers in this assay, from the lowest: compound 3; then compounds 1 and 2 (each within the scatter of the next).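

In this assay this aromatic carbon is no longer flat: 3-methylphenyl in place of 4-bromophenyl gives a 4.0-fold lower number from compound 2 to compound 3 (0.60 log units; beyond the scatter) and 3-methylphenyl in place of 4-fluorophenyl gives a 2.9-fold lower number from compound 1 to compound 3 (0.46 log units; beyond the scatter), both modest, while the exchange of one halogen for the other gave only a 1.4-fold higher number from compound 1 to compound 2 (0.14 log units; within the scatter). The aryl group at this place can therefore move the number beyond the scatter, and among the three compounds the lower number goes with the only one that has no halogen and the only one with its substituent at the 3-position of the phenyl ring. No measurement of any other kind bears on why the number falls.

The change swaps the halogen for methyl and shifts the ring position in one step, so the compounds shown do not separate the two; 4-methylphenyl and 3-bromophenyl would be the groups that do. Also open, as far as these compounds go, is how a 3-aminophenyl, a 3-carboxyphenyl or a longer chain such as 3-ethylphenyl would read at this carbon in this assay.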